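The compounds below may be only part of what the source reports. "The series", "measured", "known", "first", "only" and "open" are said of these compounds alone.

Compound 1: `Cc1ccc(-c2nc3ccccc3s2)cc1NC(=O)c1cnccc1Cl`; in a physicochemical assay for solubility, in phosphate buffer, measured as kinetic solubility, with a stated time of 18 h, at pH 7.4 (a lower number here means a less soluble compound, a higher number a more soluble compound), compound 1 gives 140 nM.
Compound 2: `COc1ccc(-c2nc3ccccc3s2)cc1NC(=O)c1cnccc1Cl`; in this assay compound 2 gives 340 nM.

Going by the values given here, compound 2 stands highest of the two numbers measured so far; its nearest neighbour is compound 1, and the step of a 2.4-fold higher number from compound 1 to compound 2 (0.39 log units; beyond the scatter) lies beyond the scatter. Compound 3 is `O=C(Nc1cc(-c2nc3ccccc3s2)ccc1F)c1cnccc1Cl`, not yet measured in this assay. It differs from compound 2 in one place: fluoro in place of methoxy on an aromatic carbon. Among the compounds with values here, the only measured step that bears on this position is the one from compound 1 to compound 2, where methoxy in place of methyl raised the number modestly, a 2.4-fold higher number from compound 1 to compound 2 (0.39 log units; beyond the scatter). Fluoro in place of methoxy has no direct counterpart among the measured compounds, so the expectation rests on that single step alone. Since the methoxy that carried the higher number of compound 2 is now removed, the number is expected to move back down, with a step of a 1.7-fold lower number from compound 2 to compound 3 (0.23 log units; within the scatter) of modest size, close to the scatter. Compound 3 is therefore estimated at 200 nM in this assay, with a range from 80 nM to 500 nM.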

Compound 3, solubility: 180 nM
The estimate for compound 3 lay 1.1-fold (0.05 log units) above the measured number, and the stated range covers the measured number.
By their numbers in this assay, from the lowest: compounds 1, 3 and 2 (each within the scatter of the next, the first and the last beyond it).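

Fluoro, on this aromatic carbon para to the 1,3-benzothiazol-2-yl group, gives a number in this assay that cannot be told apart from either of the two groups measured before it at this position. Against methoxy the printed step stays within the scatter (a 1.9-fold lower number from compound 2 to compound 3 (0.28 log units; within the scatter)), and against methyl it does so as well (a 1.3-fold higher number from compound 1 to compound 3 (0.11 log units; within the scatter)), so the replacement of either group by fluoro registers as no clear change. The position now holds three groups, of which only methyl and methoxy stand clearly apart (a 2.4-fold higher number from compound 1 to compound 2 (0.39 log units; beyond the scatter)), and fluoro cannot be placed with one rather than the other; nothing at hand bears on why the numbers fall this way.

As far as these compounds go, all three groups leave the numbers in a narrow band, so it remains open whether an amine, a carboxylic acid or a longer chain on this same carbon would carry the number well outside that band. From the compounds shown here alone, whether the small methoxy advantage over methyl would also appear with other changes elsewhere on the shared core is equally open.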